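The source may hold more compounds than are shown below. What is called first, only, known or untested is meant among the compounds shown, and "the series" means these compounds.

Measured compounds:

compound 1, `CCCC#Cc1cn([C@@H]2O[C@H](CO)[C@@H](O)[C@H](O)[C@H]2O)c(=O)nc1N`, > 250000 nM
compound 2, `CCCCCC#Cc1cn([C@@H]2O[C@H](CO)[C@@H](O)[C@H](O)[C@H]2O)c(=O)nc1N`, > 250000 nM
compound 3, `CCCc1cc2cn([C@@H]3O[C@H](CO)[C@@H](O)[C@H](O)[C@H]3O)c(=O)nc2o1`, 173000 nM

In a functional assay on CCRF-CEM cells (Homo sapiens) for cytotoxicity, with a stated time of 72 h (a lower number here means a stronger inhibitor, a higher number a weaker inhibitor), the value for compound 1 is a limit of the assay and not a number. The value for compound 2 is likewise a limit. Among the compounds with values here, compound 3 gives the only actual number in this assay. The change from compound 1 to compound 2 is ethyl in place of hydrogen on a saturated chain carbon, three bonds along the chain from a triple-bonded carbon, and the step it made is a step that the two limits leave unreadable from compound 1 to compound 2; the reason it cannot be read is the limit of > 250000 nM in this assay, at which 2 of the 3 values shown sit. The difference between the core of compound 1 and the core of compound 3 is not broken down here.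

Compound 4, `CCCCCc1cc2cn([C@@H]3O[C@H](CO)[C@@H](O)[C@H](O)[C@H]3O)c(=O)nc2o1`, is not yet measured. It differs from compound 3 by ethyl in place of hydrogen on a saturated chain carbon, three bonds along the chain from an aromatic carbon. Within the data shown here, this is the same kind of change as the one from compound 1 to compound 2, not the same change: there the place is on a saturated chain carbon, three bonds along the chain from a triple-bonded carbon, here it is on a saturated chain carbon, three bonds along the chain from an aromatic carbon. Among the measured compounds shown here, the one measured instance of this kind of change gives no readable size, so the expected step from compound 3 to compound 4 in this assay rests only on compound 3 itself and is taken as a 1.0-fold lower number from compound 3 to compound 4 (0.01 log units; within the scatter). For compound 4 in this assay a value of about 170000 nM is expected, with a likely span from 60000 nM to 300000 nM, and there is a real chance that the assay reports only a limit, as it did for compound 1 and compound 2.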

Compound 4, half-maximal inhibitory concentration: > 250000 nM
Compound 4 was reported as a limit; the forecaster's own chance of this, stated with the estimate: 40%; at least 1.4-fold (0.16 log units) between middle value and limit.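

In this assay, ethyl in place of hydrogen on a saturated chain carbon, three bonds along the chain from an aromatic carbon, gives an at least 1.4-fold higher number from compound 3 to compound 4 (0.15 log units; that floor lies within the scatter). The value of compound 4 is a limit of the assay and not a number, so this step shows only a floor and no true size, and that floor does not establish a change beyond the usual scatter. The same kind of change on the core of compound 1 cannot be read, so the two cores neither agree nor disagree on its size, and nothing shows whether the change carries from one core to the other, because the values involved sit at one limit: the limit of > 250000 nM in this assay, at which 3 of the 4 values shown sit.

Compound 3, at 173000 nM, remains the only number in this assay, so the compounds shown leave open what true size the step to the pentyl chain has and whether any change to the core of compound 3 would give a clearly lower number. Also open, as far as these compounds go, is whether an amine or a carboxylic acid in place of the pentyl chain of compound 4, or a longer chain there, would bring a value off the limit.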